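Swapping trifluoromethyl for bromo on a phenol

This account rests on a few compounds, and the source may have more. Where it says the series, first, only, none or still open, it means among the compounds named here.

Measured so far in a physicochemical assay for lipophilicity, read by HPLC, at pH 7.4; on this read-out higher numbers stand for higher lipophilicity and lower numbers for lower lipophilicity
- compound 1 `CCC/N=C1\S/C(=C\c2ccc(O)cn2)C(=O)N1c1ccccc1C` gives 3
- compound 2 `CCC/N=C1\S/C(=C\c2ccc(O)cc2)C(=O)N1c1ccccc1C` gives 3.5
- compound 3 `CCC/N=C1\S/C(=C\c2ccc(O)c(C(F)(F)F)c2)C(=O)N1c1ccccc1C` gives 3.8

Compound 3, at 3.8, cannot be told apart from compound 2 but stands clear of compound 1 at the upper end. Compound 4 `CCC/N=C1\S/C(=C\c2ccc(O)c(Br)c2)C(=O)N1c1ccccc1C` has bromo in place of trifluoromethyl on an aromatic carbon, ortho to a hydroxy group (bromo in place of trifluoromethyl on an aromatic carbon). The closest guide is the step that put trifluoromethyl in place of hydrogen on that carbon, a number 0.30 log units higher from compound 2 to compound 3 (within the scatter). The other step, a number 0.50 log units higher from compound 1 to compound 2 (beyond the scatter), changed a different part of the molecule and says little here. Within the data shown here, no bromo compound has been measured yet. Nothing beyond the scatter is therefore expected in this assay, and the expected step is no change at the digits printed from compound 3 to compound 4 (within the scatter). Compound 4 is estimated at 3.8, with an expected range from 3.5 to 4.1.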

Compound 4, distribution coefficient: 3.9
Beside the measured number, compound 4's estimate is 0.10 log units below it, within the range that was stated.
By their numbers in this assay, from the lowest: compound 1; then compounds 2, 3 and 4 (each within the scatter of the next, the first and the last beyond it).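

In this assay, swapping trifluoromethyl for bromo on this carbon, ortho to a hydroxy group, gives a number 0.10 log units higher from compound 3 to compound 4 (within the scatter), so the two groups cannot be told apart on this read-out. Bromo in place of hydrogen gives a number 0.40 log units higher from compound 2 to compound 4 (beyond the scatter), a step that clears the scatter, which the trifluoromethyl step did not. The 3-bromo-4-hydroxyphenyl group in place of 5-hydroxypyridin-2-yl gives a number 0.90 log units higher from compound 1 to compound 4 (beyond the scatter), the widest gap among these compounds.

On these data alone, whether chloro, methyl or methoxy on this carbon would read like bromo and trifluoromethyl stays open. Nothing available explains these numbers.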